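Removing the isopropyl group from the amide of compound 1

The compounds below may be only part of what the source reports. "The series", "measured", "known", "first", "only" and "open" are said of these compounds alone.

In a functional assay on NCI-H1975 cells (Homo sapiens) for antiproliferative activity, read by CCK-8 assay, with a stated time of 72 h (on this read-out lower numbers stand for stronger inhibition of growth and higher numbers for weaker inhibition of growth), compound 1 `CCC1C(=O)N(C)c2cnc(-n3ccc4cc(C(=O)NC(C)C)ccc43)nc2N1c1ccn(C)n1` gives 12200 nM, the higher of the two numbers available. Compound 2 `CC[C@@H]1C(=O)N(C)c2cnc(-n3ccc4cc(C(=O)NC)ccc43)nc2N1C1CCCC1` gives 1370 nM, a lower number by more than the usual scatter, though it differs from compound 1 in more than one place. Compound 3 `CCC1C(=O)N(C)c2cnc(Nc3ccc(S(N)(=O)=O)cc3)nc2N1c1ccn(C)n1` is reported as "not active" (no number reported), so it offers no number for comparison.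

Compound 4 `CCC1C(=O)N(C)c2cnc(-n3ccc4cc(C(N)=O)ccc43)nc2N1c1ccn(C)n1`, still unmeasured, keeps the core of compound 1 and changes one group: hydrogen in place of isopropyl on an amide-type nitrogen. Going by the values given here, no measured pair isolates this change. Compound 2, at 1370 nM, carries a different amide group but also differs elsewhere, so it gives only a weak hint toward a lower number. In this assay, a step beyond the scatter is therefore not expected, with a slight lean toward a lower number. The expected step is a 1.5-fold lower number from compound 1 to compound 4 (0.18 log units; within the scatter). The estimate for compound 4 is 8000 nM, with an expected range of 2500 nM to 25000 nM.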

Compound 4, concentration for 50% growth inhibition: "not active" (no number reported)
The entry for compound 4 holds no number; the estimate stays without a comparison.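

Going by these compounds alone, compound 4 is reported as "not active" (no number reported) and so no step from compound 1 can be read. No evidence here bears on this result.

What the compounds shown leave open is whether the change from isopropylcarbamoyl to carbamoyl alone shifts the number in this assay on the core of compound 1.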